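Amide aryl swap on the pyrazole series: dichloro to trifluoromethyl

The source may report more compounds than this note shows. Statements on the series, on what has been measured and on what is new or still open speak of the compounds shown alone.

Measured so far:
compound 1 `COc1cc(Cl)cc(-c2nn(-c3cccc(NC(=O)c4ccc(Cl)c(Cl)c4)c3)cc2-c2ccncc2)c1` — 82.4%
compound 2 `COc1cc(Cl)cc(-c2nn(-c3cccc(NC(=O)Nc4cc(C(F)(F)F)cc(C(F)(F)F)c4)c3)cc2-c2ccncc2)c1` — 14.2%

In a functional assay on SF-268 cells (Homo sapiens) for inhibition, read by sulforhodamine B assay, with a stated time of 48 h, tested at 10 uM (a lower number here means a stronger effect, a higher number a weaker effect of the compound at the concentration tested), compound 1 gives 82.4%, the higher of the two numbers recorded so far, so the weaker effect. Compound 2 gives 14.2% in this assay, a number well beyond the scatter away from compound 1; no single-point step between these two is listed, as the two structures differ in more than one place, so only the two values themselves can be compared.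

The next compound, compound 3 `COc1cc(Cl)cc(-c2nn(-c3cccc(NC(=O)c4cccc(C(F)(F)F)c4)c3)cc2-c2ccncc2)c1`, differs from compound 1 in one place: 3-(trifluoromethyl)phenyl in place of 3,4-dichlorophenyl on a carbonyl carbon. Going by the values given here, no measured pair reports what such a change does in this assay. The expectation is that compound 3 stays near compound 1, with a step of a number 10.4 percentage points lower from compound 1 to compound 3 (beyond the scatter), leaning downward if anything and likely not beyond the scatter. For compound 3 the estimate is 72%, between 45% and 98%.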

Compound 3, a percentage reported as activity, at one concentration (the size of the read-out at that concentration, not a potency): 77.3%
Compound 3: the middle estimate sits 5.3 percentage points below what was measured, and the stated range covers the measured number.
By their numbers in this assay, from the lowest: compound 2; then compounds 3 and 1 (each within the scatter of the next).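

This is the only step among the compounds shown that changes one place: in this assay, 3-(trifluoromethyl)phenyl in place of 3,4-dichlorophenyl on a carbonyl carbon gives a number 5.1 percentage points lower from compound 1 to compound 3 (within the scatter). At this position, then, the assay does not distinguish these two substituted phenyl groups, although the entering group has 10 heavy atoms and the leaving group has 8. No measurement on hand accounts for this result.

The step does not show which structural difference goes with the value of compound 2 at 14.2%, as that compound differs from compound 1 in more than one place. Also open, from the compounds shown here alone, is what a nitrile or a carboxylic acid on this phenyl ring, or an unsubstituted phenyl on the same carbonyl carbon, would give in this assay.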